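This account rests on a few compounds, and the source may have more. Where it says the series, first, only, none or still open, it means among the compounds named here.

Working notes on the series. The shared core of compound 1 `COc1cc2c(Oc3c(F)cc(NC(=O)NN4C(=O)CSC4c4c(F)cccc4F)cc3F)ccnc2cc1OCCCN1CCCC1` carries a pyrrolidin-1-yl tail on the propoxy chain, and in a functional assay on MDA-MB-231 cells (Homo sapiens) for antiproliferative activity, read by MTT assay, with a stated time of 72 h (on this read-out lower numbers stand for stronger inhibition and higher numbers for weaker inhibition), compound 1 gives 8350 nM. Compound 3 `COc1cc2c(Oc3c(F)cc(NC(=O)NN4C(=O)CCSC4c4c(F)cccc4F)cc3F)ccnc2cc1OCCCN1CCCC1` differs from compound 1 in its thiazinanone ring, and in this assay compound 3 gives 9650 nM. The two values lie within the scatter of each other, so no order can be read from them. For compound 2 `COc1cc2c(Oc3c(F)cc(NC(=O)NN4C(=O)C(C)SC4c4c(F)cccc4F)cc3F)ccnc2cc1OCCCN1CCCC1` the result in this assay is "not determined" (no result reported), so no number is available for it. Among the measured compounds shown here, no pair of measured compounds differs in only one place, so no single-change step is available.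

Compound 4 `COc1cc2c(Oc3c(F)cc(NC(=O)NN4C(=O)CSC4c4c(F)cccc4F)cc3F)ccnc2cc1OCCCN1CCC(C)CC1` is not yet measured. It differs from compound 1 as follows: 4-methylpiperidin-1-yl in place of pyrrolidin-1-yl on a saturated chain carbon, three bonds along the chain from an oxygen on an aromatic ring. The change sits on the saturated chain carbon, three bonds along the chain from an oxygen on an aromatic ring, remote from the thiazinanone region that separates compound 1 from compound 3. Nothing in the measured compounds tests a change at this position, so no step beyond the scatter is expected. For compound 4 the estimate is 8000 nM, with a range of 3500 nM to 18000 nM, amounting to an expected step of a 1.0-fold lower number from compound 1 to compound 4 (0.02 log units; within the scatter).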

Compound 4, half-maximal inhibitory concentration: 3830 nM
Beside the measured number, compound 4's estimate is 2.1-fold (0.32 log units) above it; the measured number falls inside the stated range.
By their numbers in this assay, from the lowest: compound 4; then compounds 1 and 3 (each within the scatter of the next).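

Among the compounds shown here, the position on a saturated chain carbon, three bonds along the chain from an oxygen on an aromatic ring, had not been tested by the earlier compounds, and it proves able to move the number in this assay: 4-methylpiperidin-1-yl in place of pyrrolidin-1-yl gives a 2.2-fold lower number from compound 1 to compound 4 (0.34 log units; beyond the scatter). For the compounds shown here, this is the only single-change step so far; it lies beyond the scatter but is modest in size. The data on hand offer no explanation for this step.

The change swaps a five-membered ring for a six-membered one and adds a methyl group at once, so a plain piperidin-1-yl tail would be needed to separate the two, while morpholin-4-yl and 4-methylpiperazin-1-yl tails would show whether a second ring hetero atom is tolerated. On these data alone, whether the step carries over to the thiazinanone ring of compound 3 also remains open.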